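The compounds below may be only part of what the source reports. "The series", "measured", "known", "first", "only" and "open" are said of these compounds alone.

Measured compounds:
Compound 1, `Nc1ccc(-c2cc(=O)c3c(N)c(Cl)ccc3o2)cc1`, in a functional assay on MCF7 cells (Homo sapiens) for inhibition, in the presence of a further agent that is not named here; a lower number here means a stronger inhibitor, a higher number a weaker inhibitor: > 10000 nM
Compound 2, `Nc1ccc(-c2cc(=O)c3c(N)c(F)cc(F)c3o2)cc1`, in this assay: 46 nM

Within the data shown here, of these two results, compound 2 supplies the only actual number in this assay. Compound 1 sits at the limit of > 10000 nM in this assay, at which 1 of the 2 values shown sits, which is a limit of the assay and not a measured number. Compound 3, `Nc1ccc(-c2cc(=O)c3c(N)c(F)ccc3o2)cc1`, has not yet been tested in this assay. It differs from compound 2 in a single place: hydrogen in place of fluoro on an aromatic carbon. Among the measured compounds shown here, no pair of measured compounds differs in only one place, so there is no measured step to lean on. Compound 1 and compound 2 differ in two places at once, and their two values show one number and one limit, which gives no direct guide to the effect of removing one fluoro on its own. The expectation here is that the change from compound 2 to compound 3 weakens inhibition in this assay by a step beyond the usual scatter, though far short of the limit. Compound 3 is accordingly estimated at 150 nM, with a range from 40 nM to 1000 nM. The expected step is a 3.3-fold higher number from compound 2 to compound 3 (0.51 log units; beyond the scatter).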

Compound 3, half-maximal inhibitory concentration: 130 nM
Estimate against measurement, compound 3: 1.2-fold (0.06 log units) above, and the stated range covers the measured number.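

In this assay, hydrogen in place of fluoro on this aromatic carbon, ortho to a fused ring and para to an amino group, gives a 2.8-fold higher number from compound 2 to compound 3 (0.45 log units; beyond the scatter), so this fluoro has a modest, measurable effect but is not required for a measured value. Compound 3 also provides the first single-place comparison at the other halogen-bearing aromatic carbon, where fluoro in place of chloro gives an at least 76-fold lower number from compound 1 to compound 3 (1.88 log units; beyond the scatter), a large step and the largest change among the compounds shown. Compound 1 stands at a limit of the assay and not at a number, so this step gives only a bound on the change: the limit of > 10000 nM in this assay, at which 1 of the 3 values shown sits.

The compounds shown leave open how a bromo or methyl group would behave on either aromatic carbon, and whether hydrogen can replace the remaining fluoro. On these data alone, it also remains unknown whether the chloro-to-fluoro step would be as large with the second fluoro present, or how a hydroxyl group would compare with either amino group in this assay.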